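Adding a trimethylpyrazinylmethyl group to a cinnamamide phenol

The source may hold more compounds than are shown below. What is called first, only, known or untested is meant among the compounds shown, and "the series" means these compounds.

Of the compounds shown here, three have been measured so far. Compound 1 `COc1cc(CNC(=O)/C=C/c2cccc(O)c2)ccc1OCc1nc(C)c(C)nc1C` carries a free hydroxy group on one aromatic ring and a (3,5,6-trimethylpyrazin-2-yl)methyl group on another. In a functional assay on SH-SY5Y cells (Homo sapiens) for cytotoxicity, read by MTT assay, with stated times of 24 h and 4 h (on this read-out higher numbers stand for an effect only at larger amounts of compound and lower numbers for an effect already at smaller amounts), compound 1 gives 3680 nM. Compound 2 `COc1cc(CNC(=O)/C=C/c2cccc(OCc3nc(C)c(C)nc3C)c2)ccc1OCc1nc(C)c(C)nc1C` differs from compound 1 by (3,5,6-trimethylpyrazin-2-yl)methyl in place of hydrogen on an oxygen on an aromatic ring and in this assay compound 2 gives 8700 nM, so that a 2.4-fold higher number from compound 1 to compound 2 (0.37 log units; beyond the scatter). Compound 3 `COc1ccc(/C=C/C(=O)NCc2ccc(O)c(OC)c2)cc1` has a different core; the difference between the two cores is not broken down here. In this assay compound 3 gives 11400 nM, which stands close to compound 2 and clearly apart from compound 1.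

Compound 4 `COc1ccc(/C=C/C(=O)NCc2ccc(OCc3nc(C)c(C)nc3C)c(OC)c2)cc1` is not yet measured. It differs from compound 3 by (3,5,6-trimethylpyrazin-2-yl)methyl in place of hydrogen on an oxygen on an aromatic ring, the same change that turned compound 1 into compound 2. Because that step was a 2.4-fold higher number from compound 1 to compound 2 (0.37 log units; beyond the scatter), a step of similar size is expected here, so that a 2.1-fold higher number from compound 3 to compound 4 (0.32 log units; beyond the scatter) is the estimated change. On that basis compound 4 is expected to give about 24000 nM in this assay, most likely between 10000 nM and 55000 nM.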

Compound 4, half-maximal effective concentration: 5050 nM
Estimate against measurement, compound 4: 4.8-fold (0.68 log units) above; the measured number lies below the stated range.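

In this assay, the change of hydrogen to (3,5,6-trimethylpyrazin-2-yl)methyl on an oxygen on an aromatic ring does not carry over unchanged from one core to the other: the same change on two cores in this assay, a 2.4-fold higher number (0.37 log units; beyond the scatter) from compound 1 to compound 2 and a 2.3-fold lower number (0.35 log units; beyond the scatter) from compound 3 to compound 4, 5.3-fold (0.73 log units) apart, beyond the scatter of two such steps. The new step, a 2.3-fold lower number from compound 3 to compound 4 (0.35 log units; beyond the scatter), runs opposite to the earlier one, while a 1.4-fold higher number from compound 1 to compound 4 (0.14 log units; within the scatter) leaves those two compounds, which differ by 4-methoxyphenyl in place of 3-hydroxyphenyl, without a readable difference. So an effect of this change seen on one core cannot simply be transferred to another in this series, but two pairs give no rule for a further core and do not show what in the cores sets the direction.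

The compounds shown leave open how a group other than (3,5,6-trimethylpyrazin-2-yl)methyl would behave on the same oxygen on either core, for example a chain ending in an amine or a carboxylic acid. They also leave open whether a third core would follow compound 2 or compound 4 in the direction of its step.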